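The source may report more compounds than this note shows. Statements on the series, on what has been measured and on what is new or still open speak of the compounds shown alone.

Compound 2 `CCCC(CC)n1ccc2cc(/C(C)=C/C(=O)Nc3ccccc3OCCCC(=O)O)ccc21` stands lowest of the two numbers in an assay on Prostate gland for inhibition of steroid 5-alpha-reductase (Rattus norvegicus) (on this read-out higher numbers stand for weaker inhibition and lower numbers for stronger inhibition), giving 9.3 nM. Compound 1 `CCC(C)n1ccc2cc(/C(C)=C/C(=O)Nc3ccccc3OCCCC(=O)O)ccc21` gives 67 nM; the step of a 7.2-fold lower number from compound 1 to compound 2 (0.86 log units; beyond the scatter) arose from ethyl in place of hydrogen on a saturated chain carbon, two bonds along the chain from an aromatic nitrogen. Compound 3 `CCC(c1ccccc1)n1ccc2cc(/C(C)=C/C(=O)Nc3ccccc3OCCCC(=O)O)ccc21` differs from compound 2 by phenyl in place of propyl on a saturated chain carbon bound to an aromatic nitrogen and a saturated chain carbon. Going by the values given here, only the step from compound 1 to compound 2 bears on this, and loosely, since it lengthened the chain rather than exchanging propyl for phenyl. For compound 3 a step of a 1.0-fold lower number from compound 2 to compound 3 (0.01 log units; within the scatter) is expected, within the scatter. Compound 3 is estimated at 9 nM, range 3 nM to 30 nM.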

Compound 3, half-maximal inhibitory concentration: 19 nM
The estimate for compound 3 lay 2.1-fold (0.32 log units) below the measured number; low and high end bracket the measured number.
By their numbers in this assay, from the lowest: compound 2; then compound 3; then compound 1.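

Phenyl is accepted on this saturated chain carbon, although propyl gives the lower number: the exchange gives a 2.0-fold higher number from compound 2 to compound 3 (0.31 log units; beyond the scatter), a modest loss. Against methyl, phenyl still gives a 3.5-fold lower number from compound 1 to compound 3 (0.55 log units; beyond the scatter), so a ring at this place keeps part of the gain seen with the longer open chain of compound 2. No measurement at hand speaks to the cause of these steps.

Open, from the compounds shown here alone, are a phenyl ring carrying chlorine or methoxy, a benzyl group on this carbon, and an amine on the chain.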